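This account rests on a few compounds, and the source may have more. Where it says the series, first, only, none or still open, it means among the compounds named here.

Values measured so far in a functional assay on Hep cells (Homo sapiens) for cytotoxicity, read by sulforhodamine B assay, with a stated time of 48 h; a higher number here means a weaker inhibitor, a lower number a stronger inhibitor:
- compound 1 `O=C(c1cccnc1)c1ccccc1O` gives 31000 nM
- compound 2 `O=C(c1cccnc1)c1cc(Cl)ccc1O` gives 27000 nM
- compound 3 `Cc1ccc(O)c(C(=O)c2cccnc2)c1` gives 11000 nM

Compound 1 stands at 31000 nM in this assay and is level with compound 2 within the scatter, while compound 3 shows a lower number. Putting chloro in place of hydrogen on an aromatic carbon gives a 1.1-fold lower number from compound 1 to compound 2 (0.06 log units; within the scatter) and so no real change. Putting methyl in place of hydrogen on an aromatic carbon gives a 2.8-fold lower number from compound 1 to compound 3 (0.45 log units; beyond the scatter) which is a modest move.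

Compound 4 `C=CCOc1ccccc1C(=O)c1cccnc1` has not yet been measured. It carries allyl in place of hydrogen on an oxygen on an aromatic ring and so hydroxy becomes allyloxy. Among the measured compounds shown here, no measured step touches that oxygen, so the data offer only a loose guide. They show how far small changes to the core of compound 1 have moved the number, and the largest such move is a 2.8-fold lower number from compound 1 to compound 3 (0.45 log units; beyond the scatter) in size. A modest shift towards a lower number is therefore expected, although a shift the other way cannot be excluded. The estimated change is a 1.9-fold lower number from compound 1 to compound 4 (0.29 log units; within the scatter) and it remains an expectation. For compound 4 the expected value is 16000 nM with an estimated range from 6000 nM to 40000 nM until a measurement is available.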

Compound 4, half-maximal inhibitory concentration: > 100000 nM
Compound 4: only a limit was reported; the forecaster's own chance of this, stated with the estimate: 15%; at least 6.2-fold (0.79 log units) between middle value and limit.
By their numbers in this assay, from the lowest: compound 3; then compounds 2 and 1 (each within the scatter of the next). At a limit, above all of these: compound 4.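

In this assay compound 4 gives no number but only a limit: the limit of > 100000 nM in this assay, at which 1 of the 4 values shown sits.

Among the compounds shown here, putting allyl on the oxygen gives an at least 3.2-fold higher number from compound 1 to compound 4 (0.50 log units; beyond the scatter), and this is the first change to the core of compound 1 that raises the number beyond the scatter, so a weaker result appears here for the first time. The earlier steps, all made on aromatic carbons, left the number level or lowered it, so the oxygen on the aromatic ring is now shown to be a place where a change can push the result the other way. Since hydroxy becomes allyloxy in one move, the hydrogen leaves and the allyl enters together, and this single step cannot tell which of the two matters, while the limit leaves the full size of the step unknown.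

The compounds shown leave open whether a smaller group on that oxygen, such as methyl or ethyl, would also raise the number. They also leave open what an amine or a carboxylic acid at the end of a longer chain on that oxygen would do.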